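Adding a phenyl on the chain carbon of compound 3

A few compounds are considered here, and "the series" means these few. Any claim that something is new, unique, unknown or untested is made for them only; others in the source may bear on it.

Of the compounds shown here, three have been measured in an assay on liver for inhibition of sterol O-acyltransferase 1 (Rattus norvegicus), using microsomes; on this read-out higher numbers stand for weaker inhibition and lower numbers for stronger inhibition. Compound 1 `CCCCCCCCCCCCn1nnc(C(C(=O)NC2CC2)c2ccccc2)n1` gives 244 nM, compound 2 `CCCCCCCCCCCCc1nnn(CC(=O)Nc2c(C(C)C)cccc2C(C)C)n1` gives 6 nM, and compound 3 `CCCCCCCCCCCCc1nnn(CC(=O)Nc2c(OC)cc(OC)cc2OC)n1` gives 56 nM. On these numbers compound 3 stands second highest of the three: its nearest neighbour is compound 1 with a higher number beyond the scatter, and its furthest is compound 2 with a lower number, also beyond the scatter. The three share a core and differ in the group on the amide nitrogen.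

Compound 4 `CCCCCCCCCCCCc1nnn(C(C(=O)Nc2c(OC)cc(OC)cc2OC)c2ccccc2)n1` has not yet been measured in this assay . It differs from compound 3 in one place: phenyl in place of hydrogen on a saturated chain carbon bound to an aromatic nitrogen and a carbonyl carbon. Among the measured compounds shown here, no measured pair shows this change on this core, and compound 1, which carries a phenyl on a chain carbon, also differs elsewhere, so its value of 244 nM gives no clean guide. A modest step in either direction, possibly none beyond the scatter, is expected. For compound 4 the estimated value is 80 nM, between 20 nM and 300 nM, which would mean an expected step of a 1.4-fold higher number from compound 3 to compound 4 (0.15 log units; within the scatter).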

Compound 4, half-maximal inhibitory concentration: 21 nM
The estimate for compound 4 lay 3.8-fold (0.58 log units) above the measured number; low and high end bracket the measured number.
By their numbers in this assay, from the lowest: compound 2; then compound 4; then compound 3; then compound 1.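

In this assay, phenyl in place of hydrogen on a saturated chain carbon bound to an aromatic nitrogen and a carbonyl carbon gives a 2.7-fold lower number from compound 3 to compound 4 (0.43 log units; beyond the scatter). Among the compounds shown here, this is the first single-place step in the set, and it shows that this carbon can carry a phenyl with a modest gain in inhibition rather than a loss. The earlier compounds shown here could not show this, since the phenyl of compound 1 comes with other differences. Nothing measured here accounts for the gain.

From the compounds shown here alone, whether a methyl, a benzyl or a pyridyl on the same carbon would give a like step remains open. So does whether the phenyl would also lower the number when the amide nitrogen carries the group found in compound 2.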